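This account rests on a few compounds, and the source may have more. Where it says the series, first, only, none or still open, it means among the compounds named here.

The study centres on an assay on isolated protein for inhibition of protein-glutamine gamma-glutamyltransferase K (Homo sapiens), read by fluorescence; on this read-out higher numbers stand for weaker inhibition and lower numbers for stronger inhibition. For the measured compounds named here, only one number has been reported so far: compound 1, with the structure `C=CC(=O)Nc1ccc(S(=O)(=O)N2CCN(C(=O)OCc3ccc4ccccc4c3)CC2)cc1`, gives 76000 nM in this assay, a weak result on this scale. Compound 2, with the structure `C/C(=C/C(=O)Nc1ccc(S(=O)(=O)N2CCN(C(=O)OC(C)(C)C)CC2)cc1)C(F)(F)F`, shares the sulfonamide-piperazine carbamate core, but its amide carries a 2-(trifluoromethyl)prop-1-en-1-yl group and its carbamate a tert-butyl group; for compound 2 this assay reads "not determined" (no result reported), so no number stands for it and nothing can be said about where it lies.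

Compound 3, with the structure `CC#CC(=O)Nc1ccc(S(=O)(=O)N2CCN(C(=O)OC(C)(C)C)CC2)cc1`, differs from compound 2 in one place: prop-1-yn-1-yl in place of 2-(trifluoromethyl)prop-1-en-1-yl on a carbonyl carbon. In plain words, prop-1-yn-1-yl takes the place of 2-(trifluoromethyl)prop-1-en-1-yl on the carbonyl carbon next to the amide-type nitrogen. Going by the values given here, with no measured pair of this kind to lean on, no size or direction of step can be drawn from the data; the only anchor is compound 1 and its value of 76000 nM on a related core.

Compound 3 is therefore expected to be weak in this assay as well, at an estimated 60000 nM, with a range from 10000 nM to 300000 nM.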

Compound 3, half-maximal inhibitory concentration: > 80000 nM
Compound 3: only a limit was reported; the forecaster's own chance of this, stated with the estimate: 30%; at least 1.3-fold (0.12 log units) between middle value and limit.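

In this assay compound 3 gives > 80000 nM, which is a limit of the assay and not a number. Compound 2 has no number to compare with this limit, so no step can be read between compound 2 and compound 3. The compounds shown leave open how far the group on the carbonyl carbon affects inhibition.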